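The compounds below may be only part of what the source reports. "The series", "measured", "known", "first", "only" and "open" are said of these compounds alone.

Measured in a functional assay on MT4 cells (Homo sapiens) for cytotoxicity, read by MTT assay, with a stated time of 72 h; on this read-out higher numbers stand for weaker inhibition and lower numbers for stronger inhibition:
compound 1 `Cc1c(C)c2c(c(C)c1OC(=O)CCC(=O)NC1CC(C)(C)N([O])C(C)(C)C1)CC[C@@](C)(CCC[C@H](C)CCC[C@H](C)CCCC(C)C)O2`: 53000 nM
compound 2 `Cc1c(C)c2c(c(C)c1O)CCC(C)(C(=O)NC1CC(C)(C)N([O])C(C)(C)C1)O2`: 55000 nM
compound 3 `Cc1c(C)c2c(c(C)c1O)CCC(C)(C(=O)NCC1CC(C)(C)N([O])C1(C)C)O2`: 231000 nM

In this assay compound 1 gives 53000 nM, which lies within the scatter of compound 2 at 55000 nM, so these two cannot be ranked. Compound 3 reads 231000 nM, a number beyond the scatter from compound 1.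

Compound 4 `Cc1c(C)c2c(c(C)c1OC(=O)CCC(=O)NC1CC(C)(C)N([O])C1(C)C)CC[C@@](C)(CCC[C@H](C)CCC[C@H](C)CCCC(C)C)O2` departs from compound 1 in a single place, on an amide-type nitrogen: a group of 10 heavy atoms (8 carbon, 1 nitrogen, 1 oxygen; one five-membered non-aromatic ring with 1 hetero atom) in place of a group of 11 heavy atoms (9 carbon, 1 nitrogen, 1 oxygen; one six-membered non-aromatic ring with 1 hetero atom), on an amide-type nitrogen. A group with one five-membered non-aromatic ring thus replaces a group with one six-membered non-aromatic ring.

Among the compounds with values here, no measured pair isolates this change. Compound 2 carries the six-membered ring and compound 3 the five-membered ring, but their structures differ in more than that ring. Within the data shown here, their values show only that compound 3 at 231000 nM has a higher number than compound 2 at 55000 nM. On that limited evidence, a modest move towards a higher number is expected, of a size close to the scatter and possibly within it. The expected step is a 1.7-fold higher number from compound 1 to compound 4 (0.23 log units; within the scatter). For compound 4 the estimated value is 90000 nM, with an expected range from 35000 nM to 230000 nM.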

Compound 4, half-maximal inhibitory concentration: 87000 nM
Compound 4: middle estimate off by 1.0-fold (0.01 log units), on the high side; low and high end bracket the measured number.
By their numbers in this assay, from the lowest: compounds 1, 2 and 4 (each within the scatter of the next); then compound 3.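

Within the data shown here, compound 1 and compound 4 are the first pair in this assay to isolate the ring on the amide-type nitrogen, and replacing the six-membered non-aromatic ring with the five-membered non-aromatic ring gives a 1.6-fold higher number from compound 1 to compound 4 (0.22 log units; within the scatter). Among these compounds, with the rest of compound 1 left unchanged, the two rings therefore cannot be ranked at this place, something the earlier compounds, which differ in more than the ring, could not show. Nothing available bears on what lies behind this reading.

The compounds shown leave open how this amide-type nitrogen responds to groups of another kind, such as an open butyl chain or a cyclohexyl ring carrying no ring nitrogen, since both groups compared here are rings with one hetero atom. From the compounds shown here alone, it also remains open whether the same ring change would read the same way on the core of compound 2, or in any assay other than this assay.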